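From Ethyl to Propyl on the Shared Core

The compounds below may be only part of what the source reports. "The series", "measured", "known", "first", "only" and "open" are said of these compounds alone.

Of the compounds shown here, two with a shared core have been measured in a functional assay on CHO-K1 cells for antagonist activity at C-X-C chemokine receptor type 3 (Homo sapiens), read by FLIPR, with a stated time of 10 min; a lower number here means a stronger inhibitor, a higher number a weaker inhibitor. Compound 1 `CCCc1ncc(-c2nc(C(F)(F)F)sc2N2CCN(C(=O)Cn3cnc4cccnc43)[C@H](C)C2)cn1` gives 3.3 nM. For the measured compounds named here, compound 2 `CCc1ncc(-c2nc(C(F)(F)F)sc2N2CCN(C(=O)Cn3nc(C)nc3C)[C@H](C)C2)cn1` gives 14 nM, the higher of the two numbers, and the gap lies beyond the scatter; since these two differ in more than one place, their values show only that compound 1 is the stronger inhibitor of the pair. Compound 3 `CCCc1ncc(-c2nc(C(F)(F)F)sc2N2CCN(C(=O)Cn3nc(C)nc3C)[C@H](C)C2)cn1` is not yet measured. It differs from compound 2 in one spot: methyl in place of hydrogen on a saturated chain carbon, two bonds along the chain from an aromatic carbon, which reads as ethyl to propyl. Compound 1 also carries the propyl and sits at the lower number, but no single step can be read from it. In this assay the expected step is a 1.8-fold lower number from compound 2 to compound 3 (0.24 log units; within the scatter), a modest move toward a lower number. Compound 3 is therefore estimated at 8 nM, within a range from 3 nM to 22 nM.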

Compound 3, half-maximal inhibitory concentration: 4.4 nM
Compound 3: the middle estimate sits 1.8-fold (0.26 log units) above what was measured; low and high end bracket the measured number.
By their numbers in this assay, from the lowest: compounds 1 and 3 (each within the scatter of the next); then compound 2.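

In this assay, for the compounds shown here, the ethyl to propyl change gives a 3.2-fold lower number from compound 2 to compound 3 (0.50 log units; beyond the scatter) and so provides the first single-change reading at this position: one added methyl on the saturated chain carbon moves the number beyond the scatter. With the propyl held in place, the step of a 1.3-fold higher number from compound 1 to compound 3 (0.12 log units; within the scatter) stays within the scatter, so the two ring-bearing groups on the saturated chain carbon bound to a carbonyl carbon, of 7 and 9 heavy atoms, cannot be told apart here. Nothing available explains how the propyl produces its step and the size of that step is all that can be read.

From the compounds shown here alone, a butyl chain or a methoxyethyl chain at this position remains open. So does whether ethyl to propyl gives a step of similar size when the group of 9 heavy atoms from compound 1 is present.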